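Returning from dibromophenyl to a single para substituent

This account rests on a few compounds, and the source may have more. Where it says the series, first, only, none or still open, it means among the compounds named here.

Compound 1 `Cc1ccc(NC(=O)COc2ccc3cc(/C=C4/SC(=O)NC4=O)ccc3c2)cc1` carries a 4-methylphenyl group on the amide-type nitrogen, and in an assay on isolated protein for inhibition of histone deacetylase 8 (Homo sapiens), with a stated time of 1 h (on this read-out lower numbers stand for stronger inhibition and higher numbers for weaker inhibition), compound 1 gives 9000 nM. Compound 2 `O=C(COc1ccc2cc(/C=C3/SC(=O)NC3=O)ccc2c1)Nc1ccc(Br)c(Br)c1` bears 3,4-dibromophenyl in the same place. In this assay compound 2 reaches only a limit of the measurement, > 50000 nM. The step of an at least 5.5-fold higher number from compound 1 to compound 2 (0.74 log units; beyond the scatter) is accordingly bounded by the limit of > 50000 nM in this assay, at which 1 of the 2 values shown sits, rather than fixed to a number. Compound 3 `COc1ccc(NC(=O)COc2ccc3cc(/C=C4/SC(=O)NC4=O)ccc3c2)cc1` reverses direction with one change: 4-methoxyphenyl in place of 3,4-dibromophenyl on an amide-type nitrogen. For the measured compounds named here, the only measured step on this nitrogen, from compound 1 to compound 2, weakened inhibition when the dibromophenyl entered, and its removal in favour of 4-methoxyphenyl, a group of the same size as the 4-methylphenyl of compound 1, is expected to regain most of that ground, with a step of an at least 5.0-fold lower number from compound 2 to compound 3 (0.69 log units; beyond the scatter) in this assay. Compound 3 is therefore estimated at 10000 nM in this assay, with a likely range from 3000 nM to 40000 nM.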

Compound 3, half-maximal inhibitory concentration: > 50000 nM
Compound 3 ended at the assay's limit; the forecaster's own chance of this, stated with the estimate: 20%; middle value at least 5.0-fold (0.69 log units) from the limit.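

In this assay, methoxy in place of methyl on an aromatic carbon gives an at least 5.5-fold higher number from compound 1 to compound 3 (0.74 log units; beyond the scatter), a step bounded by a limit of the assay and not fixed to a number. The loss seen with 3,4-dibromophenyl therefore did not need bromine: this one change on the ring is enough, and of the three groups shown on the amide-type nitrogen, only 4-methylphenyl gives a readable value. The comparison of compound 2 with compound 3 cannot be read, because both stand at the same limit: the limit of > 50000 nM in this assay, at which 2 of the 3 values shown sit.

Going by these compounds, whether a plain phenyl, a 4-ethylphenyl or a 4-chlorophenyl on this nitrogen would keep a readable value stays open, as does the effect of an amine or a carboxylic acid on the ring. On these data alone, how far compound 2 and compound 3 lie past the limit also remains unknown.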